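A few compounds are considered here, and "the series" means these few. Any claim that something is new, unique, unknown or untested is made for them only; others in the source may bear on it.

Measured compounds:
- compound 1, `O=C(Nn1c(-c2cccc([N+](=O)[O-])c2)nc2c(-c3ccc(Cl)cc3)n[nH]c2c1=O)c1ccccc1`: 18500 nM
- compound 2, `CCCc1nc2c(-c3ccc(Cl)cc3)n[nH]c2c(=O)n1NC(=O)c1ccccc1`: 9260 nM

In a functional assay on HT-29 cells (Homo sapiens) for inhibition, read by MTT assay, with a stated time of 2 days (on this read-out higher numbers stand for weaker inhibition of growth and lower numbers for stronger inhibition of growth), compound 2 and compound 1 give numbers within the scatter of each other, so neither stands apart. Compound 3, `CCCCc1nc2c(-c3ccc(Cl)cc3)n[nH]c2c(=O)n1NC(=O)c1ccccc1`, differs from compound 2 by methyl in place of hydrogen on a saturated chain carbon, three bonds along the chain from an aromatic carbon. Going by the values given here, the only measured step, a 2.0-fold lower number from compound 1 to compound 2 (0.30 log units; within the scatter), concerns a different group and says nothing about lengthening this chain, so no guide exists for this change. The expected step is therefore a 1.0-fold lower number from compound 2 to compound 3 (0.01 log units; within the scatter), nothing beyond the scatter. Compound 3 is estimated at 9000 nM, ranging from 3000 nM to 27000 nM.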

Compound 3, concentration for 50% growth inhibition: 710 nM
Compound 3: the middle estimate sits 13-fold (1.10 log units) above what was measured; measured number outside the range, below it.
By their numbers in this assay, from the lowest: compound 3; then compounds 2 and 1 (each within the scatter of the next).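

In this assay, the chain position turns out to be sensitive: going from propyl to butyl, a single added methyl, gives a 13-fold lower number from compound 2 to compound 3 (1.12 log units; beyond the scatter). Butyl also separates clearly from 3-nitrophenyl at this place, with a 26-fold lower number from compound 1 to compound 3 (1.42 log units; beyond the scatter), whereas propyl stayed within the scatter of that group. No measurement shown gives a reason for this jump. As far as these compounds go, whether a longer chain such as pentyl lowers the number further, or whether a branched chain or an amine at the same place keeps the gain, remains open.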